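This account rests on a few compounds, and the source may have more. Where it says the series, first, only, none or still open, it means among the compounds named here.

Compound 2 `COc1cccc(OC)c1OCCNCCOc1ccccc1OCc1ccccc1C` belongs to a small series built around a shared core in which a benzyl ether carries a single substituent. Among the compounds with values here, in a functional assay on Vas deferens for antagonist activity at Alpha-1A adrenergic receptor (Rattus norvegicus) (a higher number here means a more potent compound, by a factor of ten per unit of this negative logarithm, a lower number a less potent compound), compound 2 gives 7.81, the lowest of the two numbers measured so far. Its nearest neighbour is compound 1 `COc1cccc(OC)c1OCCNCCOc1ccccc1OCc1ccccc1Cl`, which in this assay gives 8.56. Within the data shown here, the one step connecting them is a number 0.75 log units lower from compound 1 to compound 2 (beyond the scatter), so swapping chloro for methyl on that aromatic carbon cost potency modestly but clearly.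

Compound 3 `COc1cccc(OC)c1OCCNCCOc1ccccc1OCc1cccc([N+](=O)[O-])c1` has not yet been measured. It differs from compound 2 by 3-nitrophenyl in place of 2-methylphenyl on a saturated chain carbon bound to an oxygen on an aromatic ring. Among the measured compounds shown here, only the step from compound 1 to compound 2 bears on this change, and it shows that a change of substituent on that benzyl ring moves potency by a modest amount, though in that case the substituent stayed at the same place and here both the group and its position change. The expected step of a number 0.09 log units higher from compound 2 to compound 3 (within the scatter) is therefore small, with no firm direction, and compound 3 is estimated to give 7.9 in this assay, within a range from 7.3 to 8.6.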

Compound 3, negative logarithm of the antagonist equilibrium constant: 8.85
The estimate for compound 3 lay 0.95 log units below the measured number, and the stated range ends below it.
By their numbers in this assay, from the lowest: compound 2; then compounds 1 and 3 (each within the scatter of the next).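

In this assay, the result shows that this place on the shared core accepts a much bigger change than chloro to methyl without any loss: the step is a number 1.04 log units higher from compound 2 to compound 3 (beyond the scatter) and it is large. The other step, a number 0.29 log units higher from compound 1 to compound 3 (within the scatter), leaves 3-nitrophenyl and 2-chlorophenyl level although they differ in both the group and its place on the ring, so compound 2 alone stands lower among the three. Nothing available gives a reason for this pattern.

Because the group and its place on the ring change together in this step, the compounds shown cannot separate the contribution of the nitro group from that of its place, and 3-methylphenyl or 2-nitrophenyl would be needed to pull the two apart. From the compounds shown here alone, it also stays open whether this place accepts groups of a different kind, such as a 3-aminophenyl with its amine or a 3-carboxyphenyl with its carboxylic acid, since three compounds cover only a narrow range of substituents.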